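Swapping an amino-linked chain for an ether-linked ring

A few compounds are considered here, and "the series" means these few. Any claim that something is new, unique, unknown or untested is made for them only; others in the source may bear on it.

Of the compounds shown here, three sharing one core have been tested in a functional assay on RS4-11 cells (Homo sapiens) for inhibition, read by CCK-8 assay, with a stated time of 72 h; a lower number here means a stronger inhibitor, a higher number a weaker inhibitor. Compound 1 `CC1(C)CCC(CN2CCN(c3ccc(C(=O)NS(=O)(=O)c4ccc(NCC5CCOCC5)c([N+](=O)[O-])c4)c(Oc4cnc5[nH]ccc5c4)c3)CC2)=C(c2ccc(C(F)(F)F)c(Cl)c2)C1` gives 81 nM. Compound 2 `CN(C)CCCNc1ccc(S(=O)(=O)NC(=O)c2ccc(N3CCN(CC4=C(c5ccc(C(F)(F)F)cc5)CC(C)(C)CC4)CC3)cc2Oc2cnc3[nH]ccc3c2)cc1[N+](=O)[O-]` gives 3.9 nM. Compound 3 `CCN(CC)CCCNc1ccc(S(=O)(=O)NC(=O)c2ccc(N3CCN(CC4=C(c5ccc(C(F)(F)F)cc5)CC(C)(C)CC4)CC3)cc2Oc2cnc3[nH]ccc3c2)cc1[N+](=O)[O-]` gives 3 nM, the lowest of the three numbers; its gap to compound 2 lies within the scatter, while compound 1 sits beyond it at a far higher number.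

Among the measured compounds shown here, the one step between neighbours that differ in a single place, a 1.3-fold lower number from compound 2 to compound 3 (0.11 log units; within the scatter), shows that enlarging the amine at the end of the chain left this assay unchanged. Compound 4 `CCN1CCC(COc2ccc(S(=O)(=O)NC(=O)c3ccc(N4CCN(CC5=C(c6ccc(C(F)(F)F)cc6)CC(C)(C)CC5)CC4)cc3Oc3cnc4[nH]ccc4c3)cc2[N+](=O)[O-])CC1` differs from compound 3 in (1-ethylpiperidin-4-yl)methoxy in place of (3-(diethylamino)propyl)amino on an aromatic carbon. For the measured compounds named here, this change is larger than the one in the measured step: the link to the aromatic ring changes as well as the group beyond it, and no measured pair shows that kind of swap on its own. The measured step therefore offers only weak guidance, and compound 1 differs from compound 3 in several places at once.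

Given this, compound 4 is expected to stay close to compound 3, with a modest rise allowed for the untested linkage, estimated at a 2.3-fold higher number from compound 3 to compound 4 (0.37 log units; beyond the scatter). The value for compound 4 is estimated at 7 nM, within a range of 2 nM to 25 nM.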

Compound 4, half-maximal inhibitory concentration: 4.9 nM
Compound 4: middle estimate off by 1.4-fold (0.15 log units), on the high side, within the range that was stated.
By their numbers in this assay, from the lowest: compounds 3, 2 and 4 (each within the scatter of the next); then compound 1.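

The earlier step altered only the end of the chain, while this one alters the whole group on the aromatic carbon ortho to the nitro group: the open chain gives way to a six-membered non-aromatic ring, and the amino link gives way to an ether oxygen, leaving 0 hydrogen-bond donors in this group where there was 1. Even so, this assay shows a 1.6-fold higher number from compound 3 to compound 4 (0.21 log units; within the scatter), and against the dimethylamino chain it shows a 1.3-fold higher number from compound 2 to compound 4 (0.10 log units; within the scatter), so in these three compounds neither the amino link nor the open chain is needed for a low number at this position. No measurement at hand explains this result.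

On these data alone, the linkage and the ring changed together, so the effect of each alone stays open; a (1-ethylpiperidin-4-yl)methylamino group, which pairs the same ring with the amino link, would separate them. Also open, as far as these compounds go, is whether an amine at the end of the group matters at all, a question that a plain propoxy chain or a morpholine ring in its place would address.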